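Trimming a Ring Down to a Hydroxy Group

A few compounds are considered here, and "the series" means these few. Any claim that something is new, unique, unknown or untested is made for them only; others in the source may bear on it.

Of the compounds shown here, three sharing one core have been measured in a physicochemical assay for lipophilicity, at pH 7.4; a higher number here means a more lipophilic compound, a lower number a more polar compound. Compound 2 `CNC(=O)c1cc(C(=O)NCCC2CCOCC2)cn(Cc2ccccc2)c1=O` gives 3.6, level with compound 1 `CNC(=O)c1cc(C(=O)NC2CCC2)cn(Cc2cccc(NC)c2)c1=O` at 3.6; together these are the highest two numbers. Compound 3 `CNC(=O)c1cc(C(=O)NC2CC2)cn(Cc2ccc3nc[nH]c3c2)c1=O` stands far lower, at 1.2. The next compound, compound 4 `CNC(=O)c1cc(C(=O)NCCO)cn(Cc2ccccc2)c1=O`, has not been measured. It differs from compound 2 in one place: hydroxy in place of oxan-4-yl on a saturated chain carbon, two bonds along the chain from an amide-type nitrogen. A six-heavy-atom ring leaves and a single oxygen with a hydrogen-bond donor enters, so a clearly lower reading in this assay is expected, a step well beyond the scatter. For compound 4 the expected value is 1.8, within a range from 1.2 to 2.4. This estimate means a drop a number 1.80 log units lower from compound 2 to compound 4 (beyond the scatter).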

Compound 4, distribution coefficient: 1.9
The estimate for compound 4 lay 0.10 log units below the measured number; the range from low to high includes it.
By their numbers in this assay, from the lowest: compound 3; then compound 4; then compounds 1 and 2 (each within the scatter of the next).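

Placing hydroxy instead of oxan-4-yl on this saturated chain carbon gives, in this assay, a number 1.70 log units lower from compound 2 to compound 4 (beyond the scatter). Going by these compounds alone, this is the first pair here that differs in one place, so it shows that this position alone can move the number by a large step while the rest of the molecule stays the same. Nothing available explains the size of this step.

From the compounds shown here alone, whether a methoxy group or an amine in the same place would read closer to compound 2 or to compound 4 remains open. So does the effect of a longer chain carrying the hydroxy.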